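The source may hold more compounds than are shown below. What is called first, only, known or untested is meant among the compounds shown, and "the series" means these compounds.

Working notes on the series. Three analogues of one shared core differ only in the group on an aromatic carbon of a six-membered aromatic ring of carbon only, para to a large group. Compound 1 `O=[N+]([O-])c1ccc(-c2csc(N3N=C(c4ccc(N5CCCCC5)cc4)CC3c3ccc(Cl)cc3)n2)cc1` gives in a functional assay on A549 cells (Homo sapiens) for antiproliferative activity, read by MTT assay, with a stated time of 72 h (a lower number here means a stronger inhibitor, a higher number a weaker inhibitor), only a limit, > 100000 nM. Compound 2 `Clc1ccc(-c2csc(N3N=C(c4ccc(N5CCCCC5)cc4)CC3c3ccc(Cl)cc3)n2)cc1` gives 46400 nM and compound 3 `FC(F)(F)c1ccc(-c2csc(N3N=C(c4ccc(N5CCCCC5)cc4)CC3c3ccc(Cl)cc3)n2)cc1` gives 42000 nM; compound 3 holds the lowest of the two numbers, with compound 2 nearest, the step of a 1.1-fold lower number from compound 2 to compound 3 (0.04 log units; within the scatter). The steps of an at least 2.1-fold lower number from compound 1 to compound 2 (0.33 log units; beyond the scatter) and an at least 2.3-fold lower number from compound 1 to compound 3 (0.37 log units; beyond the scatter) are at least modest and are bounded by the limit of > 100000 nM in this assay, at which 1 of the 3 values shown sits. Compound 4 `CS(=O)(=O)c1ccc(-c2csc(N3N=C(c4ccc(N5CCCCC5)cc4)CC3c3ccc(Cl)cc3)n2)cc1` differs from compound 3 by methylsulfonyl in place of trifluoromethyl on an aromatic carbon. For the measured compounds named here, no measured step touches methylsulfonyl; the one number-to-number comparison in the set lies within the scatter. The step of a 1.4-fold higher number from compound 3 to compound 4 (0.15 log units; within the scatter) is therefore expected to be small, a modest rise not excluded and a limit possible. Compound 4 is estimated at 60000 nM, within 25000 nM to 150000 nM.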

Compound 4, half-maximal inhibitory concentration: > 100000 nM
Compound 4 ended at the assay's limit; the forecaster's own chance of this, stated with the estimate: 30%; at least 1.6-fold (0.22 log units) between middle value and limit.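

In this assay the value of compound 4 is a limit and not a number, the second such value in the series: the limit of > 100000 nM in this assay, at which 2 of the 4 values shown sit. Methylsulfonyl on this aromatic carbon gives an at least 2.3-fold higher number from compound 3 to compound 4 (0.37 log units; beyond the scatter) and an at least 2.1-fold higher number from compound 2 to compound 4 (0.33 log units; beyond the scatter), so a second group besides nitro now separates from chloro and trifluoromethyl. The step between compound 1 and compound 4 cannot be read, since both values are limits.

Nitro and methylsulfonyl therefore stay unranked. On these data alone, whether an amine or a carboxylic acid at this place would fall with chloro and trifluoromethyl, or at the limit, stays open.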